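The source may report more compounds than this note shows. Statements on the series, on what has been measured and on what is new or still open speak of the compounds shown alone.

Measured compounds:
- compound 1, `Cc1cc(C)c(N2CCN(c3ncccn3)CC2)nn1`: > 100000 nM
- compound 2, `Cc1cc(-c2ccncc2)nnc1N1CCN(c2ncccn2)CC1`: > 100000 nM

Both compounds were tested in a functional assay on BV-2 cells (Mus musculus) for inhibition, read by ELISA, with a stated time of 16 h; on this read-out lower numbers stand for stronger inhibition and higher numbers for weaker inhibition. Compound 1 gives > 100000 nM, which is a limit of the assay and not a number. Compound 2 likewise gives > 100000 nM, again a limit and not a number. Going by the values given here, the only measured step, a step that the two limits leave unreadable from compound 1 to compound 2, therefore cannot be sized, because the limit of > 100000 nM in this assay, at which 2 of the 2 values shown sit, holds both values and neither is a real number. So compound 2 stands at the assay limit, with no measured activity to build on.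

Compound 3, `Cc1cc(-c2ccc3[nH]ccc3c2)nnc1N1CCN(c2ncccn2)CC1`, has not yet been measured. It differs from compound 2 in one place: 1H-indol-5-yl in place of pyridin-4-yl on an aromatic carbon. The step from compound 1 to compound 2 is the only one bearing on this position, and its size is unreadable, so it gives no direction for the change in this assay. With nothing measured beyond the limit, compound 3 is expected to stay near that limit as well, with the step of a number no higher from compound 2 to compound 3 (the limit leaves the size open) estimated as none beyond the scatter. Compound 3 is thus estimated at 100000 nM, within a range of 10000 nM to 300000 nM.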

Compound 3, half-maximal inhibitory concentration: 85100 nM
Compound 3: middle estimate off by 1.2-fold (0.07 log units), on the high side; the range from low to high includes it.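

In this assay, going by these compounds alone, compound 3 gives 85100 nM, the first real number in this set, so this position on the shared core can hold a group that brings the read-out within the measurable range. The change from pyridin-4-yl to 1H-indol-5-yl gives an at least 1.1-fold lower number from compound 2 to compound 3 (0.07 log units; that floor lies within the scatter), and the change from methyl to 1H-indol-5-yl gives an at least 1.1-fold lower number from compound 1 to compound 3 (0.07 log units; that floor lies within the scatter). The true size of both steps stays open because compound 1 and compound 2 each stand at a limit and not at a number: the limit of > 100000 nM in this assay, at which 2 of the 3 values shown sit.

The compounds shown leave open which feature of 1H-indol-5-yl matters, as it differs from pyridin-4-yl both in its added five-membered ring and in its hydrogen-bond donor. A naphthalen-2-yl group, with two fused carbon rings and no nitrogen, would help to separate these two features, while a plain phenyl group would show how much a single carbon ring does at this position.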